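The source may report more compounds than this note shows. Statements on the series, on what has been measured and on what is new or still open speak of the compounds shown alone.

In a functional assay on LNCaP cells (Homo sapiens) for cytotoxicity (a higher number here means a weaker inhibitor, a lower number a stronger inhibitor), compound 1 (`CNC(=O)Nc1ccc(-c2nc(N3CC4CCC(C3)O4)c3cnn(CCN(C)C)c3n2)cc1`) gives 400 nM, the highest of the three numbers measured. Compound 2 (`O=C(Nc1ccc(-c2nc(N3CC4CCC(C3)O4)c3cnn(C4CCC5(CC4)OCCO5)c3n2)cc1)Nc1cccnc1`) gives 1 nM and compound 3 (`CCNC(=O)Nc1ccc(-c2nc(N3CC4CCC(C3)O4)c3cnn(C4CCC5(CC4)OCCO5)c3n2)cc1`) gives 1 nM. The gaps between compound 1 and these two compounds lie far beyond the scatter. Compound 4 (`CNC(=O)Nc1ccc(-c2nc(N3CC4CCC(C3)O4)c3cnn([C@H]4CC[C@H](O)CC4)c3n2)cc1`) departs from compound 1 in one place: 4-hydroxycyclohexyl in place of 2-(dimethylamino)ethyl on an aromatic nitrogen. For the measured compounds named here, the only measured step, no change at the digits printed from compound 2 to compound 3 (within the scatter), lies elsewhere and does not test this change. Still, compound 3 carries a six-membered ring on that same nitrogen and reads 1 nM, so a large downward move is expected, an estimated 40-fold lower number from compound 1 to compound 4 (1.60 log units; beyond the scatter). Compound 4 is therefore expected at about 10 nM, with an estimated range of 2 nM to 60 nM.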

Compound 4, half-maximal inhibitory concentration: 20 nM
For compound 4 the middle estimate is 2.0-fold (0.30 log units) below the measured one; low and high end bracket the measured number.
By their numbers in this assay, from the lowest: compounds 2 and 3 (each within the scatter of the next); then compound 4; then compound 1.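

In this assay, for the compounds shown here, putting 4-hydroxycyclohexyl in place of 2-(dimethylamino)ethyl on the aromatic nitrogen gives a 20-fold lower number from compound 1 to compound 4 (1.30 log units; beyond the scatter), the first direct reading of this position. With the rest of the molecule held constant, the group on this nitrogen alone moves the number well beyond the scatter. Nothing available explains the size of this step. The step changes the ring and the hydroxyl together, and their separate contributions remain unresolved. Going by these compounds, whether a plain cyclohexyl or a 4-aminocyclohexyl on this nitrogen would read like compound 4 stays open, as does the role of the two stereocentres.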